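The source may hold more compounds than are shown below. What is called first, only, known or untested is meant among the compounds shown, and "the series" means these compounds.

Three compounds have been measured in a functional assay on CHO-K1 cells for agonist activity at Glucose-dependent insulinotropic receptor (Homo sapiens), read by a luciferase reporter, with a stated time of 5 h; a lower number here means that less compound is needed, a higher number that more compound is needed for the effect:

Compound 1, `CC(C)OC(=O)N1CCC(Oc2ncnc3c2CCN3c2ccc(S(C)(=O)=O)cc2F)CC1`, gives 50.1 nM.
Compound 2, `COC(=O)N1CCC(Oc2ncnc3c2CCN3c2ccc(S(C)(=O)=O)cc2F)CC1`, gives 316 nM.
Compound 3, `CC(C)COC(=O)N1CCC(Oc2ncnc3c2CCN3c2ccc(S(C)(=O)=O)cc2F)CC1`, gives 25.1 nM.

All three share one core and differ only in the alkyl group on the oxygen next to the carbonyl. Compound 3 sits at the low end of these numbers, but a 2.0-fold lower number from compound 1 to compound 3 (0.30 log units; within the scatter) lies within the scatter, so compound 1 and compound 3 cannot be told apart; the gap to compound 2 is clear, since a 13-fold lower number from compound 2 to compound 3 (1.10 log units; beyond the scatter).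

Compound 4, `CC(C)(C)COC(=O)N1CCC(Oc2ncnc3c2CCN3c2ccc(S(C)(=O)=O)cc2F)CC1`, continues the same series: methyl in place of hydrogen on a saturated chain carbon bound to three saturated chain carbons. Within the data shown here, two measured steps bear on it. Growing the group from methyl to isopropyl gave a clear change, a 6.3-fold higher number from compound 1 to compound 2 (0.80 log units; beyond the scatter) read in reverse, and a 13-fold lower number from compound 2 to compound 3 (1.10 log units; beyond the scatter) was larger still. Yet the most recent extension, from isopropyl to isobutyl, gave only a 2.0-fold lower number from compound 1 to compound 3 (0.30 log units; within the scatter), within the scatter. The added methyl in compound 4 is a smaller change than either earlier one, so in this assay a step no larger than the scatter is expected, if anything toward a lower number: a 1.3-fold lower number from compound 3 to compound 4 (0.10 log units; within the scatter).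

Compound 4 is therefore estimated at 20 nM, expected to fall between 8 nM and 60 nM.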

Compound 4, half-maximal effective concentration: 39.8 nM
Estimate against measurement, compound 4: 2.0-fold (0.30 log units) below; the measured number falls inside the stated range.
By their numbers in this assay, from the lowest: compounds 3, 4 and 1 (each within the scatter of the next); then compound 2.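

In this assay, adding methyl to the isobutyl group of compound 3 to give the neopentyl group of compound 4 changes little, as a 1.6-fold higher number from compound 3 to compound 4 (0.20 log units; within the scatter) stays inside the usual scatter. The same holds for the comparison with isopropyl, where a 1.3-fold lower number from compound 1 to compound 4 (0.10 log units; within the scatter) also stays inside the scatter, while the distance from the small methyl group remains clear, with a 7.9-fold lower number from compound 2 to compound 4 (0.90 log units; beyond the scatter) beyond the scatter. So compound 2 now stands apart, and compounds 1, 3 and 4 cannot be told apart, which means that the clear effect of size seen on going up from methyl does not continue through the larger groups on this oxygen next to a carbonyl group, and no measurement shown gives a reason for this.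

As far as these compounds go, it remains open whether this flat stretch extends to other groups on the same oxygen, such as a longer chain like n-hexyl, a cyclohexyl ring or a benzyl group. From the compounds shown here alone, it is also open whether the pattern would persist if the oxygen itself were replaced by an amine nitrogen, or if the rest of the shared core were changed.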